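This account rests on a few compounds, and the source may have more. Where it says the series, first, only, none or still open, it means among the compounds named here.

Of the compounds shown here, three from this series have been tested in a functional assay on Jurkat cells (Homo sapiens) for cytotoxicity; on this read-out higher numbers stand for weaker inhibition and lower numbers for stronger inhibition. Compound 1 `C/C=C/C1=C(CO)[C@@H](O)[C@@H]2O[C@@H]2C1=O` gives 60000 nM. For compound 2 `O=C1C=C(CO)[C@H](O)[C@H]2O[C@@H]12` the assay reports only a limit, > 80000 nM, as noted in the limit of > 80000 nM in this assay, at which 1 of the 3 values shown sits. Compound 3 `CCCC/C=C/C1=C(CO)[C@H](O)[C@H]2O[C@H]2C1=O` gives 15000 nM, the lowest of the two numbers, and its gap to compound 1 lies beyond the usual scatter. Compound 4 `O=C1C(/C=C/c2ccccc2)=C(CO)[C@H](O)[C@H]2O[C@@H]12` has not yet been measured. It differs from compound 3 in one place: phenyl in place of butyl on a double-bonded chain carbon bound to a double-bonded chain carbon. Among the measured compounds shown here, with no measured pair that mirrors this change, the step from compound 3 to compound 4 in this assay is estimated to be modest and toward a lower number, as a 1.5-fold lower number from compound 3 to compound 4 (0.18 log units; within the scatter) expresses. Compound 4 is therefore expected to give about 10000 nM, with a likely range from 3000 nM to 40000 nM.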

Compound 4, half-maximal inhibitory concentration: 20000 nM
Beside the measured number, compound 4's estimate is 2.0-fold (0.30 log units) below it; low and high end bracket the measured number.
By their numbers in this assay, from the lowest: compounds 3 and 4 (each within the scatter of the next); then compound 1. At a limit, above all of these: compound 2.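

Replacing butyl with phenyl on a double-bonded chain carbon bound to a double-bonded chain carbon gives, in this assay, a 1.3-fold higher number from compound 3 to compound 4 (0.12 log units; within the scatter) and so shows that this place accepts an aromatic ring as well as an open chain without a change that stands out from the scatter. Nothing measured here speaks to why the two groups read alike. Still open, from the compounds shown here alone, is whether an amine, a carboxylic acid or a chain longer than butyl at this place would move the number beyond the scatter.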